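Adding Chlorines to the Nitrogen Ring of Compound 1

The compounds below may be only part of what the source reports. "The series", "measured", "known", "first", "only" and "open" are said of these compounds alone.

In an ADME assay on MT4 cells (Homo sapiens) for cytotoxicity, read by MTT assay (a lower number here means that less compound is tolerated, a higher number that more compound is tolerated), compound 1 (`O=C1c2ccccc2C(=O)N1CCOC(=S)N(C(=O)c1ccc([N+](=O)[O-])cc1)c1ccc(Cl)cc1`) gives > 100000 nM, which is a limit of the assay and not a number. This puts compound 1 at the limit of > 100000 nM in this assay, at which 1 of the 3 values shown sits. Two relatives have true numbers: compound 2 (`O=C1c2ccccc2C(=O)N1CCOC(=S)N(C(=O)c1cccc(F)c1F)c1ccc(Cl)cc1`) gives 58000 nM, and compound 3 (`O=C1c2ccccc2C(=O)N1CCOC(=S)N(C(=O)c1ccc(F)c(F)c1)c1ccc(Cl)cc1`) gives 52000 nM.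

Compound 4 (`O=C1c2ccccc2C(=O)N1CCOC(=S)N(C(=O)c1ccc([N+](=O)[O-])cc1)c1c(Cl)cc(Cl)cc1Cl`) has 2,4,6-trichlorophenyl in place of 4-chlorophenyl on an amide-type nitrogen. Among the compounds with values here, no measured step touches that group. All three change the group on a carbonyl carbon instead, so they bear on this change only indirectly. They are an at least 1.7-fold lower number from compound 1 to compound 2 (0.23 log units; that floor lies within the scatter), an at least 1.9-fold lower number from compound 1 to compound 3 (0.28 log units; that floor lies within the scatter) and a 1.1-fold lower number from compound 2 to compound 3 (0.05 log units; within the scatter). Each is small or has a floor inside the scatter, so they offer no reason to expect a large change. A modest move to a lower number is expected, or none beyond the scatter, and the assay may again report only a limit. The expected step is an at least 1.4-fold lower number from compound 1 to compound 4 (0.15 log units; that floor lies within the scatter). For compound 4 the estimate is 70000 nM, with an expected range from 25000 nM to 100000 nM.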

Compound 4, half-maximal cytotoxic concentration: 20000 nM
Compound 4: the middle estimate sits 3.5-fold (0.54 log units) above what was measured; measured number outside the range, below it.
By their numbers in this assay, from the lowest: compound 4; then compounds 3 and 2 (each within the scatter of the next). At a limit, above all of these: compound 1.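

Within the data shown here, the group on the amide-type nitrogen had no measured step until now, and in this assay changing 4-chlorophenyl to 2,4,6-trichlorophenyl gives an at least 5.0-fold lower number from compound 1 to compound 4 (0.69 log units; beyond the scatter). Unlike the steps on the carbonyl carbon, this one lies clearly beyond the scatter, so the nitrogen substituent is a place where a single change can make cells tolerate less compound. The value of compound 1 is a limit of the assay and not a number, so this step is only a floor: the limit of > 100000 nM in this assay, at which 1 of the 4 values shown sits.

With only one change shown at this nitrogen, it remains open whether all the added chlorines are needed, or whether methyl groups in their place would give a similar step. As far as these compounds go, it also remains open whether the same change would act alike with the 2,3-difluorophenyl group of compound 2 on the carbonyl carbon.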